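Urea replacing amide on the aminopyridine series

This account rests on a few compounds, and the source may have more. Where it says the series, first, only, none or still open, it means among the compounds named here.

Measured so far:
compound 1, `COc1cccc(-c2nn(-c3ccccc3)cc2-c2ccnc(NCCCNC(=O)c3cccc(C(F)(F)F)c3)c2)c1`: 17000 nM
compound 2, `COc1cccc(-c2nn(-c3ccccc3)cc2-c2ccnc(NCCNC(=O)Nc3cccc(C(F)(F)F)c3)c2)c1`: 1620 nM

In a functional assay on SNB-75 cells (Homo sapiens) for antiproliferative activity (a higher number here means a weaker inhibitor of growth, a lower number a stronger inhibitor of growth), compound 1 gives 17000 nM, the higher of the two numbers recorded. Going by the values given here, compound 2, which carries a urea on a shorter chain, gives 1620 nM in this assay, a gap from compound 1 that lies beyond the scatter; no single-point step between the two is defined, so only the two values themselves can be read.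

Compound 3, `COc1cccc(-c2nn(-c3ccccc3)cc2-c2ccnc(NCCCNC(=O)Nc3ccc(Cl)c(Cl)c3)c2)c1`, has not yet been measured. Relative to compound 1 the change is (3,4-dichlorophenyl)amino in place of 3-(trifluoromethyl)phenyl on a carbonyl carbon. The propylene chain of compound 1 is kept, while the amide becomes a urea, as in compound 2, and the aryl substitution is altered.

The urea-bearing compound 2 sits well below compound 1, so an improvement from compound 1 to compound 3 in this assay is expected, of the order a 4.9-fold lower number from compound 1 to compound 3 (0.69 log units; beyond the scatter), though the changed aryl group leaves the size uncertain. Compound 3 is therefore estimated at 3500 nM in this assay, with a range from 900 nM to 14000 nM.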

Compound 3, concentration for 50% growth inhibition: 2520 nM
For compound 3 the middle estimate is 1.4-fold (0.14 log units) above the measured one; the range from low to high includes it.
By their numbers in this assay, from the lowest: compounds 2 and 3 (each within the scatter of the next); then compound 1.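

In this assay the exchange of (3-(trifluoromethyl)phenyl)carbonyl for (3,4-dichlorophenyl)carbamoyl, with the propylene chain kept, gives a 6.7-fold lower number from compound 1 to compound 3 (0.83 log units; beyond the scatter), so a gain over compound 1 at this position does not depend on the shorter chain of compound 2. The step is composite: the amide becomes a urea, the aryl substitution changes from trifluoromethyl to two chlorines, and the entering group carries 1 hydrogen-bond donor where the leaving group carries 0, so the gain cannot be assigned to any one of these parts. Nothing available explains the gain in terms of a measured property of either group.

A urea bearing 3-(trifluoromethyl)phenyl on the propylene chain, or an amide bearing 3,4-dichlorophenyl on that chain, would be needed to split the step into its linker and aryl contributions. Also open, going by these compounds, is how the series responds to a longer butylene chain, or to an amine or a carboxylic acid on the aryl ring in place of the chlorines.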